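From Fluoro to Trifluoromethyl at an Assay Limit

This account rests on a few compounds, and the source may have more. Where it says the series, first, only, none or still open, it means among the compounds named here.

Three compounds share one core here: compound 1 (`C=C[C@@](C)(/C=C/c1ccc(Nc2ccccc2)cc1)CCC=C(C)C`), compound 2 (`C=C[C@@](C)(/C=C/c1ccc(Nc2ccc(F)cc2)cc1)CCC=C(C)C`) and the still unmeasured compound 3 (`C=C[C@@](C)(/C=C/c1ccc(Nc2ccc(C(F)(F)F)cc2)cc1)CCC=C(C)C`). In a functional assay on Raji cells (Homo sapiens) for cytotoxicity, with a stated time of 72 h (a higher number here means that more compound is needed for the effect, a lower number that less compound is needed), compound 1 gives > 26000 nM, which is a limit and not a number. In this assay compound 2 gives > 26000 nM, again a limit, so compound 2 has no exact value on the numbers shown.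

Compound 3 differs from compound 2 at one spot: trifluoromethyl in place of fluoro on an aromatic carbon. This puts trifluoromethyl in place of fluoro on an aromatic carbon, para to a large group. Within the data shown here, the one measured step that bears on this is a step that the two limits leave unreadable from compound 1 to compound 2, where fluoro replaces hydrogen on an aromatic carbon, and its size cannot be read. Compound 1 and compound 2 both sit at the same point, (the limit of > 26000 nM in this assay, at which 2 of the 2 values shown sit). That gives no direction for the next change, so no step beyond the usual scatter is expected. The expected step is a step that the limit leaves unreadable from compound 2 to compound 3. For compound 3 the estimate is 30000 nM, with an expected range from 12000 nM to 70000 nM.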

Compound 3, half-maximal effective concentration: > 26000 nM
Compound 3 gave a limit, no number; the forecaster's own chance of this, stated with the estimate: 75%; the middle value does not contradict the limit.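

In this assay, among these compounds, compound 1, compound 2 and compound 3 all stop at a limit and not a number, so no step between them can be read. The compounds shown leave open whether hydrogen, fluoro and trifluoromethyl on this aromatic carbon differ at all in this assay and how much of each compound the effect needs.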